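From a Dichlorophenyl Urea to a Simple Benzamide

This account rests on a few compounds, and the source may have more. Where it says the series, first, only, none or still open, it means among the compounds named here.

Among the compounds with values here, compound 1 `COc1cc(-c2nn(-c3cccc(NC(=O)Nc4ccc(Cl)c(Cl)c4)c3)cc2-c2ccncc2)ccc1Cl` gives 5190 nM in a functional assay on NCI-H23 cells (Homo sapiens) for inhibition, read by sulforhodamine B assay, with a stated time of 48 h (on this read-out lower numbers stand for stronger inhibition of growth and higher numbers for weaker inhibition of growth), and stands second highest of the three numbers measured so far; compound 3 `O=C(Nc1cccc(-n2cc(-c3ccncc3)c(-c3ccc(Cl)c(O)c3)n2)c1)Nc1cc(C(F)(F)F)cc(C(F)(F)F)c1` gives 3270 nM and compound 2 `O=C(Nc1cccc(-n2cc(-c3ccncc3)c(-c3ccc(Cl)c(O)c3)n2)c1)Nc1ccc(Cl)c(Cl)c1` gives 29100 nM. Compound 4 `COc1cc(-c2nn(-c3cccc(NC(=O)c4ccccc4)c3)cc2-c2ccncc2)ccc1Cl` differs from compound 1 by phenyl in place of (3,4-dichlorophenyl)amino on a carbonyl carbon. Within the data shown here, no measured step mirrors this change: the only step, a 5.6-fold higher number from compound 1 to compound 2 (0.75 log units; beyond the scatter), alters a different part of the molecule, and compounds 2 and 3 show only that the outer ring can shift the number. With a donor and two chlorines gone, the step is expected to be a loss, a 2.3-fold higher number from compound 1 to compound 4 (0.36 log units; beyond the scatter). Compound 4 is therefore estimated at 12000 nM, within a range from 4000 nM to 40000 nM.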

Compound 4, concentration for total growth inhibition: > 100000 nM
Compound 4 was reported as a limit (the forecaster's own chance of this, stated with the estimate: 10%); at least 8.3-fold (0.92 log units) between middle value and limit.
By their numbers in this assay, from the lowest: compounds 3 and 1 (each within the scatter of the next); then compound 2. At a limit, above all of these: compound 4.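

Compound 4 reaches only a limit of the assay, not a measured number: the limit of > 100000 nM in this assay, at which 1 of the 4 values shown sits. Phenyl in place of (3,4-dichlorophenyl)amino on a carbonyl carbon gives an at least 19-fold higher number from compound 1 to compound 4 (1.28 log units; beyond the scatter), so what sits on this carbonyl carbon strongly affects growth inhibition, a step that compounds 2 and 3 could not reveal. This single change removes the amino group and both chlorines together.

The compounds shown leave open which of these losses matters. A plain phenylamino group or a 3,4-dichlorophenyl group on the same carbonyl carbon would separate them.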